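Trimming One Methyl from the Enamide Chain of Compound 3

This account rests on a few compounds, and the source may have more. Where it says the series, first, only, none or still open, it means among the compounds named here.

The three measured compounds share one core and differ only in the group attached to the amide carbonyl:

Compound 1 `C=C(F)C(=O)Nc1cc(Nc2nccc(-c3cn(C)c4ccccc34)n2)c(OC)cc1N(C)CCN(C)C` — in a functional assay on A549 cells (Homo sapiens) for antiproliferative activity, read by MTT assay, with a stated time of 72 h (a higher number here means a weaker inhibitor, a lower number a stronger inhibitor), compound 1 gives 2460 nM.
Compound 2 `C=C(Cl)C(=O)Nc1cc(Nc2nccc(-c3cn(C)c4ccccc34)n2)c(OC)cc1N(C)CCN(C)C` — compound 2 gives 7520 nM.
Compound 3 `COc1cc(N(C)CCN(C)C)c(NC(=O)/C=C\C(C)C)cc1Nc1nccc(-c2cn(C)c3ccccc23)n1` — compound 3 gives 612 nM.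

Compound 3 has the lowest number of the three, and both steps toward it lie beyond the scatter: a 4.0-fold lower number from compound 1 to compound 3 (0.60 log units; beyond the scatter) and a 12-fold lower number from compound 2 to compound 3 (1.09 log units; beyond the scatter). Between the two halogen-bearing compounds the step is smaller: a 3.1-fold higher number from compound 1 to compound 2 (0.49 log units; beyond the scatter). Taken together, the branched alkene chain on the carbonyl gives a clearly lower number than either halogen-bearing ethenyl group.

Compound 4 `CC/C=C\C(=O)Nc1cc(Nc2nccc(-c3cn(C)c4ccccc34)n2)c(OC)cc1N(C)CCN(C)C` keeps that alkene chain but shortens it: hydrogen in place of methyl on a saturated chain carbon bound to a double-bonded chain carbon and a saturated chain carbon. Among the measured compounds shown here, none of the measured steps touches this saturated chain carbon; all three swap the whole group on the carbonyl, so they say how much the chain matters against a halogen, not how much one methyl at its end matters. The expectation therefore rests on compound 3 and its value 612 nM, with a small step in either direction, most likely within the scatter. Compound 4 is expected to give 800 nM in this assay, between 300 nM and 2200 nM, a step of a 1.3-fold higher number from compound 3 to compound 4 (0.12 log units; within the scatter).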

Compound 4, half-maximal inhibitory concentration: 1530 nM
Beside the measured number, compound 4's estimate is 1.9-fold (0.28 log units) below it; measured number inside the range.
By their numbers in this assay, from the lowest: compound 3; then compounds 4 and 1 (each within the scatter of the next); then compound 2.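

Taking one methyl off the chain end, so that isopropyl becomes ethyl, is the first step here that changes this saturated chain carbon alone, and in this assay it gives a 2.5-fold higher number from compound 3 to compound 4 (0.40 log units; beyond the scatter), which shows that this single carbon counts on its own and that the whole of the chain's earlier advantage cannot be credited to the alkene. Without the methyl, the advantage over the fluoro compound is no longer visible, with a 1.6-fold lower number from compound 1 to compound 4 (0.21 log units; within the scatter), while the advantage over the chloro compound remains but shrinks, from a 12-fold lower number from compound 2 to compound 3 (1.09 log units; beyond the scatter) to a 4.9-fold lower number from compound 2 to compound 4 (0.69 log units; beyond the scatter). Nothing measured here explains why the methyl has this effect.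

The compounds shown leave open whether the number keeps falling as this end of the chain grows, for instance with a cyclopropyl group or a longer chain in place of the isopropyl, or whether isopropyl is already the best choice. They also leave open how an amine such as dimethylamino would behave at the same chain end.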